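Chloro Step Repeated on a Second Amide Core

The compounds below may be only part of what the source reports. "The series", "measured", "known", "first", "only" and "open" are said of these compounds alone.

Compound 1 `O=C(CCCCC1CCSS1)Nc1ccccn1` and compound 2 `O=C(CCCCC1CCSS1)Nc1ccc(Cl)cn1` share one core, and compound 2 differs from compound 1 by chloro in place of hydrogen on an aromatic carbon. In a functional assay on Bel-7402 cells (Homo sapiens) for inhibition, read by MTT assay, with a stated time of 24 h, tested at 10 ug/mL (a lower number here means less inhibition of growth, a higher number more inhibition of growth at the concentration tested), compound 1 gives 5.77%, while compound 2 gives 16.1%; the step of a number 10.3 percentage points higher from compound 1 to compound 2 (beyond the scatter).

Compound 3 `CC(=O)SCCC(CCCCC(=O)Nc1ccccc1)SC(C)=O` stands on a different core, and the difference between the two cores is not broken down here. In this assay compound 3 is reported as "not active" (no number reported), so no number is available for it. Compound 4 `CC(=O)SCCC(CCCCC(=O)Nc1ccccc1Cl)SC(C)=O` differs from compound 3 by chloro in place of hydrogen on an aromatic carbon. Among the compounds with values here, this is the same kind of change as the one from compound 1 to compound 2, but not the same: in compound 2 the chloro sits on a six-membered aromatic ring with 1 nitrogen, two atoms from the ring nitrogen and para to a large group, whereas in compound 4 it sits on a six-membered aromatic ring of carbon only, ortho to a large group.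

For compound 4 in this assay a step of about the same modest size as a number 10.3 percentage points higher from compound 1 to compound 2 (beyond the scatter) is expected, resting only on that single earlier step and on the absence of a number for compound 3, reported as "not active" (no number reported). Compound 4 is therefore estimated at 10%, expected to lie between 0% and 25%.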

Compound 4, percent growth inhibition at one concentration: 3.09%
The estimate for compound 4 lay 6.9 percentage points above the measured number; the range from low to high includes it.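

In this assay, within the data shown here, compound 4 gives 3.09% and compound 3 is reported as "not active" (no number reported) so no step from compound 3 to compound 4 can be read. The compounds shown leave open whether chloro in place of hydrogen changes growth inhibition on the core of compound 3 as it does on the core of compound 1. No evidence at hand bears on this result.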